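Phenyl for isopropyl on a carbonyl carbon: working notes

This account rests on a few compounds, and the source may have more. Where it says the series, first, only, none or still open, it means among the compounds named here.

Measured so far in a physicochemical assay for lipophilicity, read by HPLC, measured as chromatographic lipophilicity, at pH 7.4; a lower number here means a more polar compound, a higher number a more lipophilic compound
- compound 1 `O=C(c1cnco1)N1CCC(C(=O)N2N=CC[C@H]2c2ccccc2)CC1` gives 2.7
- compound 2 `CC(C)C(=O)N1N=CCC1c1ccccc1` gives 4.4
- compound 3 `O=C(c1cn[nH]c1)N1CCC(C(=O)N2N=CCC2c2ccccc2)CC1` gives 2.1

Compound 2 reads 4.4, the highest of the three numbers. Compound 1 and compound 3 both lie below it, beyond the scatter, with compound 3 the furthest away.

The next compound to be read is compound 4 `O=C(c1ccccc1)N1N=CCC1c1ccccc1`, which has phenyl in place of isopropyl on a carbonyl carbon. Within the data shown here, no two measured compounds differ in one place only, and the series therefore offers no direct precedent for this change. The expectation starts from compound 2 at 4.4 and otherwise rests on the structural change alone, which makes it a rough one. A moderate upward move in this assay is expected, beyond the scatter. The estimated size of the move is a number 0.60 log units higher from compound 2 to compound 4 (beyond the scatter). For compound 4 the expected value is 5 (estimated range 4.5 to 5.5).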

Compound 4, distribution coefficient: 4.6
Compound 4: middle estimate off by 0.40 log units, on the high side, within the range that was stated.
By their numbers in this assay, from the lowest: compound 3; then compound 1; then compounds 2 and 4 (each within the scatter of the next).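

Among these compounds, this is the first one-place comparison: in this assay, phenyl in place of isopropyl on a carbonyl carbon gives a number 0.20 log units higher from compound 2 to compound 4 (within the scatter) and so leaves the two compounds indistinguishable. At this place, with amide-type nitrogen in a ring as the other neighbour, a change from 3 heavy atoms to 6 heavy atoms and the arrival of a six-membered aromatic ring of carbon only therefore produce no readable difference in this pair. Among the compounds shown here, this single pair sets no trend, and compound 1 and compound 3 offer no one-place step with which to test it.

As far as these compounds go, whether a longer chain, an amine or a carboxylic acid on this carbonyl carbon would also leave the number within the scatter remains open. Nothing available explains why compound 2 and compound 4 read alike.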